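The compounds below may be only part of what the source reports. "The series", "measured", "known", "first", "only" and "open" are said of these compounds alone.

Compound 1 `Cc1ccccc1-n1cc(CN2C(=O)C[C@@H]3CC[C@@]2(C)C3(C)C)nn1`: 350 nM
Compound 2 `CC1(C)[C@H]2CC[C@]1(C)N(Cc1cn(-c3ccccc3)nn1)C(=O)C2`: 240 nM

Of the compounds shown here, two have been measured in a functional assay on SGC-7901 cells (Homo sapiens) for inhibition, read by MTT assay, with a stated time of 24 h; a lower number here means a stronger inhibitor, a higher number a weaker inhibitor: compound 1 gives 350 nM and compound 2 gives 240 nM. The only step between them, a 1.5-fold lower number from compound 1 to compound 2 (0.16 log units; within the scatter), lies within the scatter, so on the numbers shown compound 2 stands alongside compound 1 rather than apart from it; the two cannot be told apart.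

Compound 3 `CC1(C)[C@H]2CC[C@]1(C)N(Cc1cn(-c3ccccc3Br)nn1)C(=O)C2` is made from compound 2 by one change: bromo in place of hydrogen on an aromatic carbon. Within the data shown here, the only measured step that bears on this sits on the same kind of place, an aromatic carbon of the phenyl ring, and that step, a 1.5-fold lower number from compound 1 to compound 2 (0.16 log units; within the scatter), did not reach beyond the scatter. Among the measured compounds shown here, there is no measured step with a halogen at all, so the expectation rests on that single result. The expected step of no change at the digits printed from compound 2 to compound 3 (within the scatter) in this assay is therefore none beyond the scatter. For compound 3 the estimated value in this assay is 240 nM, with a range from 100 nM to 600 nM.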

Compound 3, half-maximal inhibitory concentration: 500 nM
Estimate against measurement, compound 3: 2.1-fold (0.32 log units) below; the measured number falls inside the stated range.
By their numbers in this assay, from the lowest: compounds 2, 1 and 3 (each within the scatter of the next, the first and the last beyond it).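

Placing bromo on this aromatic carbon, ortho to a large group, gives a 2.1-fold higher number from compound 2 to compound 3 (0.32 log units; beyond the scatter) in this assay, so this is the first change at this position to pass beyond the scatter, although the step is only a modest one. The other comparison at the same carbon, with bromo in place of methyl, gives a 1.4-fold higher number from compound 1 to compound 3 (0.15 log units; within the scatter) and does not separate the two substituents, so only the compounds with hydrogen and bromo at this position can be told apart, while the methyl compound cannot be told apart from either. Nothing available here accounts for the difference between hydrogen and bromo at this position.

From the compounds shown here alone, with only hydrogen, methyl and bromo tested at this one carbon, it remains open whether other substituents there, such as fluoro, chloro, methoxy, an amine or a carboxylic acid, would leave the number within the scatter of compound 2 or move it further. Going by these compounds, it is also open whether bromo would give a similar step on another carbon of the same ring, or whether this step belongs to this position alone.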